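Swapping a pyridine for a nitrobenzyl group on compound 2

The source may hold more compounds than are shown below. What is called first, only, known or untested is meant among the compounds shown, and "the series" means these compounds.

Compound 2 `Cc1nn(-c2nc(-c3ccc(Cl)c(Cl)c3)c(SC(C)C)s2)c(C(=O)O)c1-c1ccncc1` is the stronger of the two compounds measured in a functional assay on BJAB cells (Homo sapiens) for antiproliferative activity, with a stated time of 4 days (on this read-out higher numbers stand for an effect only at larger amounts of compound and lower numbers for an effect already at smaller amounts), where compound 2 gives 5900 nM and compound 1 `CNc1cc(-c2c(C)nn(-c3nc(-c4ccc(Cl)c(Cl)c4)c(SC(C)C)s3)c2C(=O)O)ccn1` gives 18000 nM. Within the data shown here, the only measured step, a 3.1-fold lower number from compound 1 to compound 2 (0.48 log units; beyond the scatter), concerns a different position. Compound 3 `Cc1nn(-c2nc(-c3ccc(Cl)c(Cl)c3)c(SC(C)C)s2)c(C(=O)O)c1Cc1ccccc1[N+](=O)[O-]` arises from compound 2 by 2-nitrobenzyl in place of pyridin-4-yl on an aromatic carbon. Among the measured compounds shown here, no measured step touches this position, so the outcome cannot be anchored to earlier data. The change from compound 2 to compound 3 is therefore expected to lie within the scatter, a 1.0-fold higher number from compound 2 to compound 3 (0.01 log units; within the scatter). For compound 3 the estimate in this assay is 6000 nM, spanning from 1500 nM to 25000 nM.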

Compound 3, half-maximal effective concentration: 20000 nM
Compound 3: middle estimate off by 3.3-fold (0.52 log units), on the low side, and the stated range covers the measured number.
By their numbers in this assay, from the lowest: compound 2; then compounds 1 and 3 (each within the scatter of the next).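

This carbon of the core is not indifferent to change: in this assay, 2-nitrobenzyl in place of pyridin-4-yl gives a 3.4-fold higher number from compound 2 to compound 3 (0.53 log units; beyond the scatter). The 2-nitrobenzyl and 2-(methylamino)pyridin-4-yl groups end up level, with a 1.1-fold higher number from compound 1 to compound 3 (0.05 log units; within the scatter), so among these three groups only the unsubstituted pyridin-4-yl stands apart, with the lowest number. No available measurement explains this difference.

From the compounds shown here alone, it remains open whether the loss follows the nitro group or the one-carbon link of the benzyl group. A plain benzyl or a 2-aminobenzyl group at this carbon would separate these two features.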